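Trifluoromethyl for methyl on the aryl urea of compound 1

The compounds below may be only part of what the source reports. "The series", "measured", "known", "first", "only" and "open" are said of these compounds alone.

Measured so far:
compound 1 `Cc1cccc(NC(=O)N[C@H](C)c2ccccc2)c1`: 47%
compound 2 `Cc1cccc(NC(=O)N[C@@H](C)c2ccccc2)c1`: 100%
compound 3 `C[C@@H](NC(=O)Nc1ccccc1C(C)(C)C)c1ccccc1`: 17%

Three ureas from the shared core have been run in an ADME assay on the whole organism with Oryza sativa as the target, tested at 10 uM; on this read-out higher numbers stand for a weaker effect at the one concentration tested and lower numbers for a stronger effect. Compound 1 stands second highest of the three numbers: compound 3 is nearest, with a lower number, and compound 2 is furthest, with a number 53 percentage points higher from compound 1 to compound 2 (beyond the scatter). That single measured step rests only on (the fact that compounds 1 and 2 differ only in the configuration as drawn), so it is a change of configuration and not of substituent.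

Compound 4 `C[C@@H](NC(=O)Nc1cccc(C(F)(F)F)c1)c1ccccc1` is not yet measured. Against compound 1 the change is trifluoromethyl in place of methyl on an aromatic carbon. Going by the values given here, no measured step among compounds 1, 2 and 3 exchanges one aryl substituent for another at the same place; compound 3 differs from compound 1 in more than one place and gives only its own value. The configuration step from compound 1 to compound 2 says nothing about a substituent exchange. Nothing in the measured numbers therefore points in a direction, and no step beyond the scatter is expected for compound 4, though the range must stay wide. For compound 4 the estimate in this assay is 42%, between 15% and 75%, which would be a number 5 percentage points lower from compound 1 to compound 4 (within the scatter).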

Compound 4, a percentage reported as activity, at one concentration (the size of the read-out at that concentration, not a potency): 70%
Compound 4: the middle estimate sits 28 percentage points below what was measured; the measured number falls inside the stated range.
By their numbers in this assay, from the lowest: compound 3; then compound 1; then compound 4; then compound 2.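

In this assay, going by these compounds alone, trifluoromethyl in place of methyl on this aromatic carbon gives a number 23 percentage points higher from compound 1 to compound 4 (beyond the scatter) and is the first exchange of one substituent for another at a single place. Within the data shown here, the earlier step between compounds 1 and 2 changed only the configuration as drawn, so this is the first sign that the read-out also responds to the group carried on this aromatic carbon, and here the exchange moves it towards a weaker effect at the one concentration tested. Among these compounds, nothing at hand bears on why this exchange moves the number, and the single step gives a direction for this one pair of groups only, not a trend across substituents.

Still open, from the compounds shown here alone, is whether a chlorine, a methoxy group or a nitrile on the same aromatic carbon would move the number in the same direction as trifluoromethyl, or whether plain hydrogen there would give a number closer to that of compound 1 or of compound 4. Also open, going by these compounds, is whether the exchange of methyl for trifluoromethyl would have any comparable effect in the configuration of compound 2, which gives 100% with methyl.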